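A few compounds are considered here, and "the series" means these few. Any claim that something is new, unique, unknown or untested is made for them only; others in the source may bear on it.

Measured compounds in a functional assay on NCI/ADR cells (Homo sapiens) for cytotoxicity, read by sulforhodamine B assay; on this read-out higher numbers stand for weaker inhibition of growth and lower numbers for stronger inhibition of growth:
compound 1, `CC1=CC[C@@H]([C@@](C)(O)CCCC(C)(C)NC(=S)NN)CC1`, gives 760 nM
compound 2, `CC1=CC[C@@H]([C@@](C)(O)CCCC(C)(C)NC(=S)N/N=C\c2ccc(O)cc2)CC1`, gives 8390 nM
compound 3, `CC1=CC[C@@H]([C@@](C)(O)CCCC(C)(C)NC(=S)N/N=C\c2ccccc2[N+](=O)[O-])CC1`, gives 20400 nM

Compound 1 stands lowest of these three numbers: its nearest neighbour is compound 2, reached by an 11-fold higher number from compound 1 to compound 2 (1.04 log units; beyond the scatter), and its furthest is compound 3, which differs from compound 2 by a 2.4-fold higher number from compound 2 to compound 3 (0.39 log units; beyond the scatter). The unmeasured compound 4, `CC1=CC[C@@H]([C@@](C)(O)CCCC(C)(C)NC(=S)N/N=C\c2cccc(Cl)c2)CC1`, differs from compound 1 by a group of 9 heavy atoms (7 carbon, 1 nitrogen, 1 chlorine; one six-membered aromatic ring of carbon only) in place of one nitrogen atom, on an amide-type nitrogen. The step that bears most directly on this is an 11-fold higher number from compound 1 to compound 2 (1.04 log units; beyond the scatter), where the same kind of group entered the same amide-type nitrogen of compound 1 and the number rose by a large margin; the step of a 2.4-fold higher number from compound 2 to compound 3 (0.39 log units; beyond the scatter) shows that exchanging the aromatic ring's substituent shifts the number further, though by a modest amount. On that basis a large upward step is expected in this assay, a 16-fold higher number from compound 1 to compound 4 (1.20 log units; beyond the scatter), and compound 4 is estimated at 12000 nM with a range from 5000 nM to 30000 nM.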

Compound 4, concentration for 50% growth inhibition: 7350 nM
Compound 4: the middle estimate sits 1.6-fold (0.21 log units) above what was measured; the range from low to high includes it.
By their numbers in this assay, from the lowest: compound 1; then compounds 4 and 2 (each within the scatter of the next); then compound 3.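

In this assay, replacing the amino group on the amide-type nitrogen with the 3-chlorophenyl-bearing group again gives a higher number, a 9.7-fold higher number from compound 1 to compound 4 (0.99 log units; beyond the scatter), so all three aromatic compounds shown now stand above compound 1. The substituent exchange does not always separate the aromatic compounds: 3-chlorophenyl and 4-hydroxyphenyl cannot be told apart, a 1.1-fold lower number from compound 2 to compound 4 (0.06 log units; within the scatter), whereas 2-nitrophenyl remains distinct, a 2.8-fold lower number from compound 3 to compound 4 (0.44 log units; beyond the scatter). No available evidence accounts for these differences.

The compounds shown leave open whether cyclohexyl in place of the aromatic ring, on the carbon with a double bond to nitrogen, would bring the number closer to that of compound 1. They also leave open how a carboxylic acid or an amine on the aromatic ring would register in this assay.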